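The source may hold more compounds than are shown below. What is called first, only, known or untested is meant among the compounds shown, and "the series" means these compounds.

Working notes on the series, read in an ADME assay on microsomes from liver (Homo sapiens) for metabolic stability; on this read-out higher numbers stand for a longer-lived compound and lower numbers for a shorter-lived compound. Compound 1 `CCCNC(=O)C1CCN(C(=O)c2cc3sc(C#N)cc3n2Cc2ccc(OC)cc2)CC1` gives 0.187 h. Compound 2 `CCCNC(=O)C1CC12CN(C(=O)c1cc3sc(Br)cc3n1Cc1ccc(OC)cc1)C2` gives 0.325 h, within the scatter of compound 1, so the two share the upper end of this small set. Compound 3 `CCCNC(=O)C1CCN(C(=O)c2cc(Br)cn2Cc2ccc(OC)cc2)CC1` gives 0.0362 h, lower than compound 1 by more than the scatter.

Compound 4 `CCCNC(=O)C1CCN(C(=O)c2cc3sc(C)cc3n2Cc2ccc(OC)cc2)CC1` departs from compound 1 in one place: methyl in place of cyano on an aromatic carbon, next to the ring sulfur. For the measured compounds named here, no measured pair isolates a change at this place, so the size of the step in this assay rests on judgement alone. The range is kept wide on the low side, since compound 3 at 0.0362 h shows how low a member of this series can fall. The expected outcome is a 1.4-fold lower number from compound 1 to compound 4 (0.16 log units; within the scatter), a modest move to a lower number that may well stay within the scatter. For compound 4 the estimated half-life is 0.13 h, with an expected range of 0.05 h to 0.3 h.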

Compound 4, half-life: 0.0448 h
Compound 4: middle estimate off by 2.9-fold (0.46 log units), on the high side; the whole stated range lies above it.
By their numbers in this assay, from the lowest: compounds 3 and 4 (each within the scatter of the next); then compounds 1 and 2 (each within the scatter of the next).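

In this assay, for the compounds shown here, methyl in place of cyano on an aromatic carbon, next to the ring sulfur, gives a 4.2-fold lower number from compound 1 to compound 4 (0.62 log units; beyond the scatter) and thereby provides the first measured pair that isolates a single place. With the rest of compound 1 held fixed, the half-life therefore depends on which of these two groups sits at this position, and the cyano compound is the longer-lived of the pair. Nothing measured here explains the size of this step.

As far as these compounds go, whether a fluorine, a hydroxymethyl or a carboxamide at this place would give a half-life nearer that of compound 1 or that of compound 4 remains open. Also open, from the compounds shown here alone, is whether the step would keep its size with other parts of compound 1 changed.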